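Swapping dichlorophenyl for dimethoxyphenyl on the carbonyl carbon

The compounds below may be only part of what the source reports. "The series", "measured", "known", "first", "only" and "open" are said of these compounds alone.

Of the compounds shown here, three sharing one core have been measured in a functional assay on SR cells (Homo sapiens) for cytotoxicity, read by sulforhodamine B assay, with a stated time of 48 h, tested at 10 uM; on this read-out higher numbers stand for a weaker effect at the one concentration tested and lower numbers for a stronger effect. Compound 1 `COc1ccc(-c2cc(/C=C/C(=O)c3ccc(N)cc3)[nH]n2)cc1` gives -12%, compound 2 `COc1cc(-c2cc(/C=C/C(=O)c3ccc(N)cc3)[nH]n2)cc(OC)c1OC` gives -18%, and compound 3 `COc1cc(-c2cc(/C=C/C(=O)c3ccc(Cl)c(Cl)c3)[nH]n2)cc(OC)c1OC` gives 8%, the highest of the three, beyond the scatter from both others. For the measured compounds named here, the only single-change step, a number 26 percentage points higher from compound 2 to compound 3 (beyond the scatter), came from putting 3,4-dichlorophenyl in place of 4-aminophenyl on the carbonyl carbon. Compound 4 `COc1ccc(C(=O)/C=C/c2cc(-c3cc(OC)c(OC)c(OC)c3)n[nH]2)cc1OC` differs from compound 3 in one place: 3,4-dimethoxyphenyl in place of 3,4-dichlorophenyl on a carbonyl carbon. Going by the values given here, no measured pair tests a dimethoxyphenyl, so that step is only a loose guide; the two 4-aminophenyl compounds sit lower than compound 3. For compound 4 a step of a number 8 percentage points lower from compound 3 to compound 4 (within the scatter) is expected, modestly downward and uncertain. The estimate for compound 4 is 0%, with a range from -20% to 20%.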

Compound 4, a percentage reported as activity, at one concentration (the size of the read-out at that concentration, not a potency): 2%
Beside the measured number, compound 4's estimate is 2 percentage points below it; the range from low to high includes it.
By their numbers in this assay, from the lowest: compounds 2 and 1 (each within the scatter of the next); then compounds 4 and 3 (each within the scatter of the next).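

In this assay a second group on the carbonyl carbon can now be compared with 3,4-dichlorophenyl, and the two do not separate: the data show a number 6 percentage points lower from compound 3 to compound 4 (within the scatter). Set against 4-aminophenyl, the data show a number 20 percentage points higher from compound 2 to compound 4 (beyond the scatter) and so both replacements for 4-aminophenyl give higher numbers than compound 2. No measurement here explains this difference.

As far as these compounds go, whether the lower number of compound 2 depends on the amine itself stays open. A 4-hydroxyphenyl group or a carboxylic acid on that ring could help to test this.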